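The source may report more compounds than this note shows. Statements on the series, on what has been measured and on what is new or still open speak of the compounds shown alone.

Two compounds from this series already carry a number. Compound 1, with the structure `CC(C)=CCC/C(C)=C/COc1cc(=O)n(CCCO)c2c1CC(CC=C(C)C)C(C)(C)C2`, and compound 2, with the structure `CC(C)=CCC1Cc2c(OCCCNS(=O)(=O)c3ccc(Cl)cc3)cc(=O)n(CCCO)c2CC1(C)C`, share the same core and were both tested in a functional assay on PANC-1 cells (Homo sapiens) for inhibition, read by MTT assay, with a stated time of 24 h, tested at 10 uM; on this read-out lower numbers stand for less inhibition and higher numbers for more inhibition at the one concentration tested (going by the name of the read-out). In this assay compound 1 gives 10.6%, while compound 2 gives 24.7%. Of these two numbers compound 2 stands higher, and the gap to compound 1 is beyond the scatter of repeated measurements, so compound 2 is the more inhibiting of the pair.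

The next compound, compound 3, has the structure `CC(C)=CCC1Cc2c(OCCCNC(=O)c3cccs3)cc(=O)n(CCCO)c2CC1(C)C`. It differs from compound 2 in one place: (thiophen-2-yl)carbonyl in place of (4-chlorophenyl)sulfonyl on an amine nitrogen. The rest of the molecule is unchanged.

Among the measured compounds shown here, no measured pair in this small set mirrors that exchange, so there is no direct template for the size of the step. Given that only two numbers are known, and both are modest, the step is expected to be small, either direction, and quite possibly within the scatter. The estimate for compound 3 is 18%, with a range from 5% to 34%, which corresponds to an expected step of a number 6.7 percentage points lower from compound 2 to compound 3 (within the scatter).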

Compound 3, a percentage reported as inhibition, at one concentration (the size of the read-out at that concentration, not a potency): 33.6%
Compound 3: middle estimate off by 15.6 percentage points, on the low side; measured number inside the range.
By their numbers in this assay, from the lowest: compound 1; then compounds 2 and 3 (each within the scatter of the next).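

In this assay, putting (thiophen-2-yl)carbonyl in place of (4-chlorophenyl)sulfonyl on the amine nitrogen gives a number 8.9 percentage points higher from compound 2 to compound 3 (within the scatter), so at this position neither the linking group nor the ring can yet be told apart by this read-out, even though both differ between the two compounds. The larger exchange, 2-(((thiophen-2-yl)carbonyl)amino)ethyl in place of 2,6-dimethylhepta-1,5-dien-1-yl on a saturated chain carbon bound to an oxygen on an aromatic ring, gives a number 23 percentage points higher from compound 1 to compound 3 (beyond the scatter), so in this small set the clear change comes from replacing the whole side chain and not from swapping the group at its far end. Nothing measured here explains either step.

Still open, on these data alone, is what (4-chlorophenyl)carbonyl or (thiophen-2-yl)sulfonyl on the same nitrogen would give, as these would separate the linking group from the ring, which change together between compound 2 and compound 3. Also open, as far as these compounds go, is how a free amine, a carboxylic acid or a longer chain carrying the same (thiophen-2-yl)carbonyl would read in this assay.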